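Replacing Hydroxy With Carbamoyl on the Piperidine Side Chain

A few compounds are considered here, and "the series" means these few. Any claim that something is new, unique, unknown or untested is made for them only; others in the source may bear on it.

Within the data shown here, compound 2 `O=S1(=O)Cc2nc(-c3cc(F)c(Cl)cc3F)nc(N3CCC(CO)CC3)c2C1` holds the lowest of the two numbers so far obtained in a functional assay on the whole organism (blood, strain ICR) with Mus musculus as the target, in the glucose tolerance test, with a stated time of 30 min (on this read-out lower numbers stand for an effect already at smaller amounts and higher numbers for an effect only at larger amounts of compound), where compound 2 gives 0.3 mg/kg. Its nearest neighbour, compound 1 `CN(C)C(=O)C1CCN(c2nc(-c3cc(F)c(Cl)cc3F)nc3c2CS(=O)(=O)C3)CC1`, carries dimethylcarbamoyl where compound 2 carries hydroxymethyl on a saturated ring carbon, and in this assay compound 1 gives 1 mg/kg; the step of a 3.3-fold lower number from compound 1 to compound 2 (0.52 log units; beyond the scatter) is beyond the scatter. Compound 3 `NC(=O)CC1CCN(c2nc(-c3cc(F)c(Cl)cc3F)nc3c2CS(=O)(=O)C3)CC1` differs from compound 2 in a single place: carbamoyl in place of hydroxy on a saturated chain carbon bound to a saturated ring carbon. Among the measured compounds shown here, the only measured step that bears on this change is a 3.3-fold lower number from compound 1 to compound 2 (0.52 log units; beyond the scatter), in which hydroxymethyl in place of dimethylcarbamoyl lowered the number modestly. Compound 3 brings a carbamoyl back in, though on a saturated chain carbon bound to the saturated ring carbon rather than on the ring carbon itself, so the writer expects the number to drift back upward in this assay by a step of about a 2.0-fold higher number from compound 2 to compound 3 (0.30 log units; within the scatter), at most modest and quite possibly within the scatter. Compound 3 is accordingly estimated in this assay at 0.6 mg/kg, within a range from 0.2 mg/kg to 2 mg/kg.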

Compound 3, minimum effective dose: 0.1 mg/kg
Beside the measured number, compound 3's estimate is 6.0-fold (0.78 log units) above it, and the stated range ends above it.
By their numbers in this assay, from the lowest: compound 3; then compound 2; then compound 1.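

Carbamoyl in place of hydroxy on a saturated chain carbon bound to a saturated ring carbon gives a 3.0-fold lower number from compound 2 to compound 3 (0.48 log units; beyond the scatter) in this assay and so shows that this position can take a group larger than hydroxy, with the number falling beyond the scatter. The step from compound 1 to compound 2 alone could have tied the lower number to the loss of the carbonyl-bearing group, but compound 3 keeps a carbonyl in this side chain and still holds the lowest number of the three, and carbamoylmethyl in place of dimethylcarbamoyl on a saturated ring carbon gives a 10-fold lower number from compound 1 to compound 3 (1.00 log units; beyond the scatter) in this series. Nothing given here explains either step.

Still open, as far as these compounds go, is whether the lower number of compound 3 follows the extra chain carbon or the absence of the methyl groups on the amide nitrogen, as these changes are joined in this pair. Also open, from the compounds shown here alone, is how a carboxylic acid or an amine at the end of this chain, or a longer chain carrying the carbamoyl, would read in this assay on the same core.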